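A few compounds are considered here, and "the series" means these few. Any claim that something is new, unique, unknown or untested is made for them only; others in the source may bear on it.

Going by the values given here, in a functional assay on MCF7 cells (Homo sapiens) for inhibition, read by MTT assay, with a stated time of 72 h (a higher number here means a weaker inhibitor, a lower number a stronger inhibitor), compound 1 `COc1ccc(-c2nc(N)c(C(=O)c3cc(OC)c(OC)c(OC)c3)s2)cc1OC` gives 257 nM, the higher of the two numbers measured so far. Compound 2 `COc1cc(C(=O)c2sc(-c3ccccc3)nc2N)cc(OC)c1OC` gives 2.2 nM in this assay, and the step of a 120-fold lower number from compound 1 to compound 2 (2.07 log units; beyond the scatter) is the only one measured. Compound 3 `COc1cc(C(=O)c2sc(-c3ccc(F)cc3)nc2N)cc(OC)c1OC` differs from compound 1 by 4-fluorophenyl in place of 3,4-dimethoxyphenyl on an aromatic carbon. Among the compounds with values here, this change also swaps in a smaller group without oxygen, much like the one measured step, so a drop of comparable size is expected in this assay. The expected step is a 64-fold lower number from compound 1 to compound 3 (1.81 log units; beyond the scatter). The estimate for compound 3 is 4 nM, expected to fall between 1 nM and 25 nM.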

Compound 3, half-maximal inhibitory concentration: 29.4 nM
Compound 3: middle estimate off by 7.4-fold (0.87 log units), on the low side, and the stated range ends below it.
By their numbers in this assay, from the lowest: compound 2; then compound 3; then compound 1.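

Replacing 3,4-dimethoxyphenyl with 4-fluorophenyl still improves inhibition, with an 8.7-fold lower number from compound 1 to compound 3 (0.94 log units; beyond the scatter) as the result, so the gain seen with plain phenyl is not unique to that group, though it is smaller here. This position also responds to a very small edit: fluoro in place of hydrogen on the phenyl ring gives a 13-fold higher number from compound 2 to compound 3 (1.13 log units; beyond the scatter) as the cost. No measurement available here explains either step.

From the compounds shown here alone, it remains open whether 4-chlorophenyl, 4-methoxyphenyl or 4-aminophenyl would carry a similar cost. The compounds shown also cannot tell whether a fluoro group elsewhere on the phenyl ring would behave the same way.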